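The source may hold more compounds than are shown below. What is called first, only, known or untested is meant among the compounds shown, and "the series" means these compounds.

Compound 1 `Fc1ccc(-c2nn3c(NC4CCCC4)cccc3c2-c2ccnc(NC3CCCC3)n2)cc1` in an ADME assay on Vero cells (Chlorocebus sabaeus) for cytotoxicity (on this read-out higher numbers stand for lower toxicity in this test and lower numbers for higher toxicity in this test), gives > 160000 nM and this value is a limit of the assay.
Compound 2 `COc1ccc(-c2nc3c(NC4CCCC4)cccn3c2-c2ccnc(NC3CCCC3)n2)cc1` in this assay gives > 10000 nM and this value is also a limit of the assay.

Compound 2 therefore stands at a limit only, namely (the limit of > 10000 nM in this assay, at which 1 of the 2 values shown sits). For compound 1 the record is likewise only a limit, (the limit of > 160000 nM in this assay, at which 1 of the 2 values shown sits). Among the measured compounds shown here, neither compound showed measurable toxicity within its tested range, and with two limits there is no measured step in this assay from which a direction could be read.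

Compound 3 `Oc1ccc(-c2nc3c(NC4CCCC4)cccn3c2-c2ccnc(NC3CCCC3)n2)cc1` has not yet been measured. It differs from compound 2 by hydrogen in place of methyl on an oxygen on an aromatic ring. This is a small change, one carbon removed from the edge of the molecule. Without any measured step to lean on, the expectation in this assay is a step of no more than the usual scatter, in no particular direction, and most likely another limit rather than a number. For compound 3 the estimate is 20000 nM, with an expected range from 8000 nM to 100000 nM. The expected step is a step that the limit leaves unreadable from compound 2 to compound 3.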

Compound 3, half-maximal cytotoxic concentration: > 40000 nM
Compound 3 ended at the assay's limit (the forecaster's own chance of this, stated with the estimate: 75%); at least 2.0-fold (0.30 log units) between middle value and limit.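

Among the compounds shown here, compound 2 and compound 3 both end at a limit of this assay, so no step between them can be read. The compounds shown leave open how far compound 1, compound 2 and compound 3 each lie from a concentration with measurable toxicity, and whether going from methoxy to hydroxy changes that concentration at all.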